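A few compounds are considered here, and "the series" means these few. Any claim that something is new, unique, unknown or untested is made for them only; others in the source may bear on it.

Going by the values given here, compound 1 `CC(C)c1onc(-c2c(Cl)cccc2Cl)c1COc1ccc(-c2nc3ccc(C(=O)O)cc3n2-c2ccc(F)cc2)cc1` gives 32.2 nM in an assay on Huh-7 cells for agonist activity at Bile acid receptor (Homo sapiens), read by a luciferase reporter (a lower number here means that less compound is needed, a higher number that more compound is needed for the effect), the higher of the two numbers measured so far, though compound 2 `CC(C)c1onc(-c2c(Cl)cccc2Cl)c1COc1ccc(-c2nc3ccc(C(=O)O)cc3n2C)cc1Cl`, which gives 19 nM in this assay, lies within the scatter of it. Compound 3 `CC(C)c1onc(-c2c(Cl)cccc2Cl)c1COc1ccc(-c2nc3ccc(C(=O)O)cc3n2C2CCCCC2)cc1` is the compound next to be tested. It differs from compound 1 by cyclohexyl in place of 4-fluorophenyl on an aromatic nitrogen. Among the compounds with values here, no step between measured compounds isolates this change, so the expectation rests on the spread of the two numbers alone. Compound 3 is estimated to stay close to compound 1, with the step of a 1.2-fold higher number from compound 1 to compound 3 (0.09 log units; within the scatter) expected to lie within the scatter. The value of compound 3 in this assay is estimated at 40 nM, between 12 nM and 130 nM.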

Compound 3, half-maximal effective concentration: 4.21 nM
The estimate for compound 3 lay 9.5-fold (0.98 log units) above the measured number; the measured number lies below the stated range.
By their numbers in this assay, from the lowest: compound 3; then compounds 2 and 1 (each within the scatter of the next).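

Going by these compounds alone, on the aromatic nitrogen, cyclohexyl in place of 4-fluorophenyl gives a clearly lower number in this assay, with a 7.6-fold lower number from compound 1 to compound 3 (0.88 log units; beyond the scatter), so this position responds to the group it carries, which the earlier compounds could not show. The change replaces an aromatic ring with a non-aromatic one and also removes the fluorine, and these two differences cannot be separated here. Nothing measured on these compounds explains the step.

On these data alone, it remains open whether unsubstituted phenyl would behave like 4-fluorophenyl or like cyclohexyl. As far as these compounds go, how a smaller cyclopentyl ring or an open butyl chain would fare on this nitrogen also remains open.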